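The source may hold more compounds than are shown below. What is called first, only, known or untested is meant among the compounds shown, and "the series" means these compounds.

Within the data shown here, in a functional assay on HepG2 cells (Homo sapiens) for antiproliferative activity, read by MTT assay, with a stated time of 48 h (a higher number here means a weaker inhibitor, a lower number a stronger inhibitor), compound 3 `N#CC1=C(N)Oc2c(N)cc3nc4ccccc4nc3c2C12C(=O)N(Cc1cnnn1-c1ccccc1Cl)c1ccccc12` gives 33500 nM, the only number among the three measured compounds. Compound 1 `N#CC1=C(N)Oc2c(c3nc4ccccc4nc3c3ccccc23)C12C(=O)N(Cc1cnnn1-c1ccc(Br)cc1)c1ccccc12` reaches only the assay limit of > 50000 nM. Compound 2 `N#CC1=C(N)Oc2c(c3nc4ccccc4nc3c3ccccc23)C12C(=O)N(Cc1cnnn1-c1ccc(N)cc1)c1ccccc12` likewise reaches only the assay limit of > 50000 nM. Among the measured compounds shown here, the one measured step, a step that the two limits leave unreadable from compound 1 to compound 2, is therefore hidden by the limit of > 50000 nM in this assay, at which 2 of the 3 values shown sit, and offers no readable size. Compound 4 `Cc1ccc(-n2nncc2CN2C(=O)C3(C(C#N)=C(N)Oc4c(N)cc5nc6ccccc6nc5c43)c3ccccc32)cc1C` differs from compound 3 by 3,4-dimethylphenyl in place of 2-chlorophenyl on an aromatic nitrogen. For the measured compounds named here, no measured step covers a change at this aromatic nitrogen, so the expectation is for no step beyond the usual scatter, no change at the digits printed from compound 3 to compound 4 (within the scatter). Compound 4 is accordingly expected to give about 33500 nM in this assay, within an estimated range from 12000 nM to 90000 nM.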

Compound 4, half-maximal inhibitory concentration: > 50000 nM
Compound 4 gave a limit, no number (the forecaster's own chance of this, stated with the estimate: 40%); at least 1.4-fold (0.17 log units) between middle value and limit.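

In this assay, among these compounds, replacing 2-chlorophenyl with 3,4-dimethylphenyl on the aromatic nitrogen gives the first step at this position, and it has a floor but no full size: an at least 1.4-fold higher number from compound 3 to compound 4 (0.17 log units; that floor lies within the scatter). The value of compound 4 is a limit and not a number, so this change gives no sign of a gain, and any loss remains unsized. The reading stops at the same ceiling as the earlier compounds: the limit of > 50000 nM in this assay, at which 3 of the 4 values shown sit.

From the compounds shown here alone, it remains open how far compound 4 lies past its limit. Going by these compounds, it is also open whether a phenyl ring carrying an amine or a carboxylic acid at this position would give a readable number.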